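The source may hold more compounds than are shown below. What is called first, only, known or untested is meant among the compounds shown, and "the series" means these compounds.

Measured so far:
- compound 1, `O=C(O)CC(Cc1nc2cc(C(F)(F)F)ccc2[nH]1)c1ccc(Cl)cc1`: 35% in an assay on isolated protein for inhibition of protein kinase C zeta type (Homo sapiens), read by 33P incorporation, tested at 50 uM; on this read-out lower numbers stand for a weaker effect and higher numbers for a stronger effect at the one concentration tested
- compound 2, `COc1ccc2[nH]c(CC(CC(=O)O)c3ccc(Cl)cc3)nc2c1`: 0% in this assay

Compound 2 stands lowest of the two numbers in this assay; its nearest neighbour is compound 1, which is higher by a margin beyond the scatter. Among the compounds with values here, the one step measured so far, a number 35 percentage points lower from compound 1 to compound 2 (beyond the scatter), is the whole of what is known about substitution on that aromatic carbon: the exchange of methoxy for trifluoromethyl cost a large share of the read-out.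

Compound 3, `N#Cc1ccc2[nH]c(CC(CC(=O)O)c3ccc(Cl)cc3)nc2c1`, remains to be measured in this assay. It differs from compound 2 by cyano in place of methoxy on an aromatic carbon. Within the data shown here, no measured step covers cyano, so the step from compound 1 to compound 2 bears on the new change only in that methoxy is again the group that leaves; it shows that a different group at this carbon can sit well above the value of compound 2, but it gives no direct guide to cyano. The expected step of a number 15 percentage points higher from compound 2 to compound 3 (beyond the scatter) is therefore a modest rise, held close to the scatter, with wide uncertainty. Compound 3 is estimated at 15%, within 0% to 40%.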

Compound 3, a percentage reported as inhibition, at one concentration (the size of the read-out at that concentration, not a potency): 0%
Compound 3: middle estimate off by 15 percentage points, on the high side; measured number inside the range.
By their numbers in this assay, from the lowest: compounds 2 and 3 (each within the scatter of the next); then compound 1.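

Cyano in place of methoxy on this aromatic carbon gives no change at the digits printed from compound 2 to compound 3 (within the scatter) in this assay, so a second replacement for trifluoromethyl now gives the same printed value as compound 2, and the read-out does not separate these two groups. Cyano in place of trifluoromethyl gives a number 35 percentage points lower from compound 1 to compound 3 (beyond the scatter), which matches the size of the earlier step to methoxy and leaves trifluoromethyl as the only one of the three groups whose compound stands beyond the scatter of the other two, though three compounds establish no wider rule for this position. No measurement at hand accounts for this difference between trifluoromethyl and the other two groups.

Going by these compounds, whether the read-out of compound 1 depends on trifluoromethyl itself stays open, and an amine or a sulfonamide on the same aromatic carbon would test how narrowly that holds. With all three compounds read at a single concentration, the compounds shown also give no potency for any of them, and they leave open whether compound 2 and compound 3 would remain indistinguishable under a read-out that gives one.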